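Dropping one methyl from the imidazole of compound 2

A few compounds are considered here, and "the series" means these few. Any claim that something is new, unique, unknown or untested is made for them only; others in the source may bear on it.

Measured compounds:
compound 1, `CC(C)(C)c1nccn1CCC(C(N)=O)(c1ccccc1)c1ccccc1`, 30.2 nM
compound 2, `Cc1ncn(CCC(C(N)=O)(c2ccccc2)c2ccccc2)c1C`, 2.7 nM

Both numbers come from an assay on ileum with muscarinic acetylcholine receptor M3 (Cavia porcellus) as the target; a lower number here means a stronger inhibitor, a higher number a weaker inhibitor. Among the compounds with values here, compound 2 holds the lower of the two, and the single measured step, an 11-fold lower number from compound 1 to compound 2 (1.05 log units; beyond the scatter), lies beyond the scatter. Compound 3, `Cc1cn(CCC(C(N)=O)(c2ccccc2)c2ccccc2)cn1`, is not yet measured. It differs from compound 2 by hydrogen in place of methyl on an aromatic carbon; in the words of the wider cut, 4,5-dimethyl-1H-imidazol-1-yl becomes 4-methyl-1H-imidazol-1-yl. Within the data shown here, the only measured step swaps the whole imidazole substitution pattern, so it does not directly tell what removing one methyl does; it shows only that this ring region is sensitive. A modest loss is therefore expected for compound 3, a step of a 2.6-fold higher number from compound 2 to compound 3 (0.41 log units; beyond the scatter) in this assay. The value of compound 3 is estimated at 7 nM, within 2.5 nM to 25 nM.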

Compound 3, antagonist equilibrium constant: 10.1 nM
For compound 3 the middle estimate is 1.4-fold (0.16 log units) below the measured one, and the stated range covers the measured number.
By their numbers in this assay, from the lowest: compound 2; then compound 3; then compound 1.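

In this assay, removing the methyl alone gives a 3.7-fold higher number from compound 2 to compound 3 (0.57 log units; beyond the scatter), so this single carbon has a measurable effect of its own, though hydrogen in its place still leaves a low number. The 4-methyl-1H-imidazol-1-yl group also keeps an advantage over 2-(tert-butyl)-1H-imidazol-1-yl, with a 3.0-fold lower number from compound 1 to compound 3 (0.48 log units; beyond the scatter), which splits the earlier large gap into two modest parts. No measurement here explains why the methyl matters.

Going by these compounds, the effect of an ethyl group or a chlorine atom on this same aromatic carbon remains open. So does the result for a plain 1H-imidazol-1-yl group carrying no methyl at all, which would show what the remaining methyl contributes.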